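The source may report more compounds than this note shows. Statements on the series, on what has been measured and on what is new or still open speak of the compounds shown alone.

Measured compounds in an assay on HEK293 cells for negative allosteric modulation of metabotropic glutamate receptor 5 (Homo sapiens), read by FLIPR, with a stated time of 1 h; a lower number here means a stronger inhibitor, a higher number a weaker inhibitor:
Compound 1 `O=C(C1CC12CCC2)N1CCc2nc(C#Cc3ccccc3)sc2C1`: compound 1 gives > 10000 nM, a limit of the assay rather than a number.
Compound 2 `O=C(C1CCCCC1)N1CCc2nc(C#Cc3ccccc3)sc2C1`: compound 2 gives > 10000 nM, likewise a limit of the assay.

Compound 2 therefore stands only at a limit, and the limit of > 10000 nM in this assay, at which 2 of the 2 values shown sit, shows that both measured values sit there. Among the measured compounds shown here, the one measured step, a step that the two limits leave unreadable from compound 1 to compound 2, cannot be read for size. Compound 3 `O=C(C1CCOCC1)N1CCc2nc(C#Cc3ccccc3)sc2C1` differs from compound 2 by oxan-4-yl in place of cyclohexyl on a carbonyl carbon. With no readable step to lean on, no change beyond the scatter is expected, and compound 3 is estimated at 20000 nM (range 5000 nM to 60000 nM), which would mean an expected step that the limit leaves unreadable from compound 2 to compound 3.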

Compound 3, half-maximal inhibitory concentration: > 10000 nM
Compound 3 gave a limit, no number (the forecaster's own chance of this, stated with the estimate: 80%); the middle value is on the limit's open side.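

Compound 3, like compound 1 and compound 2, gives only a limit, so no step among these compounds can be read: the limit of > 10000 nM in this assay, at which 3 of the 3 values shown sit. Going by these compounds, how far each compound lies past that limit stays open, and so does whether oxan-4-yl in place of cyclohexyl changes anything.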